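The source may hold more compounds than are shown below. What is called first, only, known or untested is meant among the compounds shown, and "the series" means these compounds.

In a functional assay on A549 cells (Homo sapiens) for antiproliferative activity, read by MTT assay (on this read-out lower numbers stand for stronger inhibition and higher numbers for weaker inhibition), compound 1 `Cn1c(=O)c(=O)n(C2CCCC2)c2nc(N/N=C/c3ccc(O)cc3)ncc21` gives > 100000 nM, which is a limit of the assay and not a number. Compound 2 `Cc1cccc(/C=N/Nc2ncc3c(n2)n(C2CCCC2)c(=O)c(=O)n3C)c1` gives 34500 nM. For the measured compounds named here, compound 3 `Cn1c(=O)c(=O)n(C2CCCC2)c2nc(N/N=C/c3ccc(Cl)cc3)ncc21` gives 6890 nM, the lowest number so far in this assay, with compound 2 as its nearest measured neighbour.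

The next change leads to compound 4 `Cn1c(=O)c(=O)n(C2CCCC2)c2nc(N/N=C/c3ccc(S(C)(=O)=O)cc3)ncc21`: methylsulfonyl in place of chloro on an aromatic carbon, para to a large group (methylsulfonyl in place of chloro on an aromatic carbon). Going by the values given here, two measured steps bear on it, as both alter the group that carries this substituent. The large step of an at least 14-fold lower number from compound 1 to compound 3 (1.16 log units; beyond the scatter) replaces hydroxy with chloro, and the modest step of a 5.0-fold lower number from compound 2 to compound 3 (0.70 log units; beyond the scatter) replaces 3-methylphenyl with 4-chlorophenyl. Neither involves methylsulfonyl, so they give only a rough guide. Both other compounds sit higher than compound 3, so a modest move to a higher number is expected here. The expected step is a 2.9-fold higher number from compound 3 to compound 4 (0.46 log units; beyond the scatter). For compound 4 the estimated value is 20000 nM, with an expected range of 6000 nM to 70000 nM.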

Compound 4, half-maximal inhibitory concentration: 84500 nM
The estimate for compound 4 lay 4.2-fold (0.63 log units) below the measured number, and the stated range ends below it.
By their numbers in this assay, from the lowest: compound 3; then compound 2; then compound 4. At a limit, above all of these: compound 1.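

In this assay, methylsulfonyl in place of chloro on an aromatic carbon, para to a large group, is a large step to weaker inhibition: a 12-fold higher number from compound 3 to compound 4 (1.09 log units; beyond the scatter). The 4-(methylsulfonyl)phenyl group also ends up weaker than 3-methylphenyl, a 2.4-fold higher number from compound 2 to compound 4 (0.39 log units; beyond the scatter), so a substituent at this place can leave the compound on either side of compound 2, with compound 3 on the stronger side and compound 4 on the weaker. Compound 1, with hydroxy at this place, gives > 100000 nM, which is a limit and not a number. The step of an at least 1.1-fold lower number from compound 1 to compound 4 (0.07 log units; that floor lies within the scatter) therefore gives only a floor: the limit of > 100000 nM in this assay, at which 1 of the 4 values shown sits.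

As far as these compounds go, whether the loss belongs to methylsulfonyl itself or would come with any group of its size remains open, as does the standing of an amine, a carboxylic acid or a methoxy group at this place. Compound 2 also differs from compound 3 in both substituent and place, so the effects of those two changes stay unseparated.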